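A few compounds are considered here, and "the series" means these few. Any claim that something is new, unique, unknown or untested is made for them only; others in the source may bear on it.

Measured so far:
compound 1 `Cc1ccc(S(=O)(=O)c2cnc3cc(F)ccc3c2N2CCC(C)CC2)cc1C` — 90%
compound 2 `Cc1ccc2ncc(S(=O)(=O)c3cc(Cl)cc(Cl)c3)c(N3CCC(C)CC3)c2c1` — 75%

In an assay on isolated protein for displacement of a labelled ligand from metabotropic glutamate receptor 5 (Homo sapiens), with a stated time of 60 min, tested at 1 uM (on this read-out lower numbers stand for less inhibition and higher numbers for more inhibition at the one concentration tested (going by the name of the read-out)), compound 1 gives 90%, the higher of the two numbers, while compound 2 gives 75%, a gap beyond the scatter. For the measured compounds named here, no measured pair differs in only one place, so no step size is known from the data. Compound 3 `CC1CCN(c2c(S(=O)(=O)c3ccc(F)c(Cl)c3)cnc3cc(F)ccc23)CC1` differs from compound 1 by 3-chloro-4-fluorophenyl in place of 3,4-dimethylphenyl on a sulfonyl sulfur. The expected step is small and downward, a number 8 percentage points lower from compound 1 to compound 3 (within the scatter), and may well fall within the scatter. In this assay compound 3 is estimated at 82%, with a range from 65% to 95%.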

Compound 3, a percentage reported as inhibition, at one concentration (the size of the read-out at that concentration, not a potency): 94%
Estimate against measurement, compound 3: 12 percentage points below; low and high end bracket the measured number.
By their numbers in this assay, from the lowest: compound 2; then compounds 1 and 3 (each within the scatter of the next).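

For the compounds shown here, replacing the group on the sulfonyl sulfur gives the first one-place comparison: 3-chloro-4-fluorophenyl in place of 3,4-dimethylphenyl gives a number 4 percentage points higher from compound 1 to compound 3 (within the scatter) in this assay. This read-out therefore does not separate the two aryl groups, so a chloro-fluoro pattern and a dimethyl pattern are both compatible with high inhibition here. Nothing available bears on the reason for this.

Open, on these data alone, is whether a cyclohexyl or pyridyl group on the sulfonyl sulfur would keep this level. Also open, as far as these compounds go, is whether full concentration-response curves would separate compound 1 and compound 3.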